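The compounds below may be only part of what the source reports. "The series", "measured", "known", "first", "only" and "open" are said of these compounds alone.

Compound 1 `CC1(C)CC(=O)C(C(=S)SCc2ccccc2)=C(Nc2ccc(Cl)cc2)C1` carries a benzylsulfanyl arm on a thiocarbonyl. In a functional assay on cells (blood, Homo sapiens) for inhibition, read by chemiluminescence, with a stated time of 30 min (a higher number here means a weaker inhibitor, a lower number a stronger inhibitor), compound 1 reaches only the limit > 100 ug/mL. Compound 2 `CC1(C)CC(=O)C(C(=S)SCCO)=C(Nc2ccc(Cl)cc2)C1` differs from it by hydroxymethyl in place of phenyl on a saturated chain carbon bound to a sulfur. In this assay compound 2 again gives only the limit > 100 ug/mL. Compound 3 `CC1(C)CC(=O)C(C(=S)SCc2ccccc2)=C(Nc2ccc(Br)cc2)C1` differs from compound 1 in the core by bromo in place of chloro on an aromatic carbon. In this assay compound 3 also gives only the limit > 100 ug/mL. The steps a step that the two limits leave unreadable from compound 1 to compound 2 and a step that the two limits leave unreadable from compound 1 to compound 3 therefore cannot be sized, because of the limit of > 100 ug/mL in this assay, at which 3 of the 3 values shown sit. Compound 4 `CC1(C)CC(=O)C(C(=S)SCCO)=C(Nc2ccc(Br)cc2)C1` has not yet been measured; it differs from compound 3 by hydroxymethyl in place of phenyl on a saturated chain carbon bound to a sulfur, the same change as from compound 1 to compound 2, now on the core of compound 3. For compound 4 the expected step is a step that the limit leaves unreadable from compound 3 to compound 4, resting on (the limit of > 100 ug/mL in this assay, at which 3 of the 3 values shown sit). In this assay compound 4 is estimated at 150 ug/mL, most likely reported as a limit only.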

Compound 4, half-maximal inhibitory concentration: > 100 ug/mL
Compound 4: only a limit was reported; the forecaster's own chance of this, stated with the estimate: 90%; the middle value is on the limit's open side.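

Compound 4, like compound 2 and compound 3, gives only a limit in this assay, so neither of its steps to those compounds can be read: the limit of > 100 ug/mL in this assay, at which 4 of the 4 values shown sit. The compounds shown leave open whether either change alters inhibition at all.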